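Working notes: 3-hydroxybenzyl to 4-aminophenyl in the series

A few compounds are considered here, and "the series" means these few. Any claim that something is new, unique, unknown or untested is made for them only; others in the source may bear on it.

Values in a functional assay on RS4-11 cells (Homo sapiens) for inhibition, read by CCK-8 assay, with a stated time of 48 h (on this read-out lower numbers stand for stronger inhibition and higher numbers for weaker inhibition), are as follows:
- compound 1 `O=C(NCCNS(=O)(=O)c1ccc(-c2ccccc2OCc2cccc(O)c2)s1)Nc1cc(C(F)(F)F)cc(C(F)(F)F)c1` gives 3000 nM
- compound 2 `O=S(=O)(NCCNC(=S)Nc1cccc(Cl)c1)c1ccc(-c2ccccc2OCc2ccccc2)s1` gives > 50000 nM (a limit of the assay, not a number)

Going by the values given here, compound 1 holds the only actual number so far in this assay and is therefore the sole numerical reference point for the series. The reading for compound 2 is a limit, so it gives no number to work from.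

The next compound to be measured is compound 3 `Nc1ccc(Oc2ccccc2-c2ccc(S(=O)(=O)NCCNC(=O)Nc3cc(C(F)(F)F)cc(C(F)(F)F)c3)s2)cc1`, which keeps the rest of compound 1 and changes in one place (4-aminophenyl in place of 3-hydroxybenzyl on an oxygen on an aromatic ring). In words, 4-aminophenyl stands in place of 3-hydroxybenzyl on an oxygen on an aromatic ring.

Among the compounds with values here, no measured pair of compounds shows a step at a single place, so the expectation rests on the structural change and on compound 1 at 3000 nM alone. In this assay, no change beyond the scatter is expected. The estimated 1.3-fold higher number from compound 1 to compound 3 (0.12 log units; within the scatter) is small, though the uncertainty is wide. For compound 3 the expected value is 4000 nM, with an estimated range of 1000 nM to 20000 nM.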

Compound 3, half-maximal inhibitory concentration: 11900 nM
Beside the measured number, compound 3's estimate is 3.0-fold (0.47 log units) below it, within the range that was stated.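

In this assay, going by these compounds alone, the change from (3-hydroxybenzyl)oxy to 4-aminophenoxy gives the first single-place step: a 4.0-fold higher number from compound 1 to compound 3 (0.60 log units; beyond the scatter). This step lies beyond the scatter, so the group on this oxygen on an aromatic ring affects the read-out, even though the rest of compound 1 is held constant and the hydrogen-bond donor and acceptor counts of the two groups match. The change weakens inhibition without taking compound 3 to the limit of the read-out, a limit that only compound 2 holds and that is not a number: the limit of > 50000 nM in this assay, at which 1 of the 3 values shown sits.

Within the data shown here, with only this one step, it remains unresolved whether the weaker reading goes with the amino group, the loss of the hydroxy group or the change from a benzyl to a phenyl group, as all three change together. Among these compounds, a hydroxyphenyl or an aminobenzyl group on the same oxygen would pull these apart, and the shared core offers no second step to show whether the effect carries over to other groups at this position.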